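The source may report more compounds than this note shows. Statements on the series, on what has been measured and on what is new or still open speak of the compounds shown alone.

In a functional assay on MDA-MB-231 cells (Homo sapiens) for inhibition, read by MTT assay, with a stated time of 72 h (a lower number here means a stronger inhibitor, a higher number a weaker inhibitor), compound 1 `COC(=O)c1ccc(-n2cc(CCCC(=O)Nc3ccc(C)cc3)nn2)cc1` gives 9700 nM and compound 3 `COC(=O)c1ccc(-n2cc(CCCNC(=O)Nc3ccc(C)cc3)nn2)cc1` gives 11600 nM as its value, the two lying within the scatter of each other, while compound 2 `COC(=O)c1ccc(-n2cc(CCCC(=O)Oc3ccc(C)cc3)nn2)cc1` gives 55100 nM in the same read-out. Compound 4 `COC(=O)c1ccc(-n2cc(CCCC(=O)NS(=O)(=O)c3ccc(C)cc3)nn2)cc1` keeps the core of compound 1 and differs on an amide-type nitrogen, with (4-methylphenyl)sulfonyl in place of 4-methylphenyl on an amide-type nitrogen as the change. Among the compounds with values here, the one measured step on this carbonyl carbon is a 5.7-fold higher number from compound 1 to compound 2 (0.75 log units; beyond the scatter) and it is modest but beyond the scatter. That step replaces the whole (4-methylphenyl)amino group, so it bears only loosely. A smaller step toward a higher number is therefore expected in this assay here. The expected value for compound 4 is 20000 nM within an estimated range from 6000 nM to 60000 nM as a working figure. That estimate means a 2.1-fold higher number from compound 1 to compound 4 (0.31 log units; beyond the scatter) as the expected step.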

Compound 4, half-maximal inhibitory concentration: > 100000 nM
Compound 4 ended at the assay's limit (the forecaster's own chance of this, stated with the estimate: 10%); middle value at least 5.0-fold (0.69 log units) away from the limit.
By their numbers in this assay, from the lowest: compounds 1 and 3 (each within the scatter of the next); then compound 2. At a limit, above all of these: compound 4.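

Compound 2 replaced the whole (4-methylphenyl)amino group, whereas here the amide-type nitrogen stays and the change on it alone, (4-methylphenyl)sulfonyl in place of 4-methylphenyl, gives an at least 10-fold higher number from compound 1 to compound 4 (1.01 log units; beyond the scatter). The series therefore responds strongly in this assay to what is carried on this nitrogen. The value of compound 4 is a limit and not a number: the limit of > 100000 nM in this assay, at which 1 of the 4 values shown sits.

Still open, going by these compounds, is whether a smaller group on this nitrogen, such as methanesulfonyl, gives the same result as (4-methylphenyl)sulfonyl. Also open, on these data alone, is how a carboxylic acid in place of the methyl ester or a longer chain would read.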